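A few compounds are considered here, and "the series" means these few. Any claim that something is new, unique, unknown or untested is made for them only; others in the source may bear on it.

Of the compounds shown here, three have been measured so far. Compound 1 `O=S(=O)(CC1=NCCO1)c1c(-c2ccccc2)nn(-c2ccccc2)c1-c1ccccc1` carries a five-membered ring with one nitrogen and one oxygen on a saturated chain carbon bound to a sulfonyl sulfur, and in a functional assay, tested at 50 ug/mL (on this read-out lower numbers stand for a weaker effect and higher numbers for a stronger effect at the one concentration tested), compound 1 gives 55.6%. Compound 3 `Cc1ccc(C2CNN=C2S(=O)(=O)CC2=NCCO2)cc1` has the same ring on the same kind of carbon but is built on a different core; how the two cores differ is not broken down here. In this assay compound 3 gives 41.3%, and compound 1 stands highest of the three, with the other two beyond the usual scatter. Compound 2 `Cc1ccc(C2CNN=C2S(=O)(=O)CC2=NCCS2)cc1` shares the core of compound 3 and differs from it by a group of 5 heavy atoms (3 carbon, 1 nitrogen, 1 sulfur; one five-membered non-aromatic ring with 2 hetero atoms) in place of a group of 5 heavy atoms (3 carbon, 1 nitrogen, 1 oxygen; one five-membered non-aromatic ring with 2 hetero atoms), on a saturated chain carbon bound to a sulfonyl sulfur. In this assay compound 2 gives 39.8%, so the step of a number 1.5 percentage points lower from compound 3 to compound 2 (within the scatter) is one that the assay cannot tell from no change at all.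

Compound 4 `O=S(=O)(CC1=NCCS1)c1c(-c2ccccc2)nn(-c2ccccc2)c1-c1ccccc1` has not yet been measured. It is made from compound 1 by the same change, (a group of 5 heavy atoms (3 carbon, 1 nitrogen, 1 sulfur; one five-membered non-aromatic ring with 2 hetero atoms) in place of a group of 5 heavy atoms (3 carbon, 1 nitrogen, 1 oxygen; one five-membered non-aromatic ring with 2 hetero atoms), on a saturated chain carbon bound to a sulfonyl sulfur), on the same kind of carbon. Going by the values given here, the one measured example of this change rests on compound 3 and compound 2, where it moved the read-out very little, because a number 1.5 percentage points lower from compound 3 to compound 2 (within the scatter) sits within the scatter. On that basis a small step is expected, a number 1.6 percentage points lower from compound 1 to compound 4 (within the scatter), in this assay. Compound 4 is therefore estimated at about 54%, most likely between 44% and 64%.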

Compound 4, a percentage reported as activity, at one concentration (the size of the read-out at that concentration, not a potency): "not active" (no number reported)
The entry for compound 4 holds no number; no gap can be computed for the estimate.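

In this assay, going by these compounds alone, compound 4 is reported only as "not active", without a number, so no step from compound 1 to compound 4 can be read. The compounds shown leave open how far compound 4 lies from compound 1 on this read-out, and whether the same group change behaves differently on the two cores. No available evidence bears on this result.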